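Removing the methyls from the piperidine of compound 3

The source may hold more compounds than are shown below. What is called first, only, known or untested is meant among the compounds shown, and "the series" means these compounds.

Compound 3 `Cc1cc(C)c(S(=O)(=O)N2CCC(N3CC(C)CC(C)C3)CC2)c(C)c1` stands second highest of the three numbers recorded in a functional assay on DLD-1 cells (Homo sapiens) for antiproliferative activity, read by CellTiter-Glo, with a stated time of 72 h (on this read-out higher numbers stand for weaker inhibition and lower numbers for stronger inhibition), where compound 3 gives 17 nM; compound 1 `Cc1cc(C)c(S(=O)(=O)N2CCC(N3CCC(C)CC3)CC2)c(C)c1` gives 0.03 nM and compound 2 `Cc1cc(C)c(S(=O)(=O)N2CCC(N3CCC(c4ccccc4)CC3)CC2)c(C)c1` gives 865 nM. Compound 4 `Cc1cc(C)c(S(=O)(=O)N2CCC(N3CCCCC3)CC2)c(C)c1` differs from compound 3 by piperidin-1-yl in place of 3,5-dimethylpiperidin-1-yl on a saturated ring carbon. The measured steps that change this same ring were both large: a 570-fold higher number from compound 1 to compound 3 (2.75 log units; beyond the scatter) and a 29000-fold higher number from compound 1 to compound 2 (4.46 log units; beyond the scatter). Both show that the pattern on this ring moves this assay strongly, but neither removes methyls entirely, so the direction for compound 4 is uncertain. The bare ring is expected to fall between compound 1 and compound 3, giving an estimated 5.7-fold lower number from compound 3 to compound 4 (0.75 log units; beyond the scatter). Compound 4 is therefore expected to give about 3 nM, within 0.1 nM to 100 nM.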

Compound 4, half-maximal inhibitory concentration: 2200 nM
Beside the measured number, compound 4's estimate is 730-fold (2.87 log units) below it, outside the stated range (above it).
By their numbers in this assay, from the lowest: compound 1; then compound 3; then compound 2; then compound 4.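

In this assay compound 4, with its bare ring, is the weakest of the four rather than a midpoint: the record shows a 130-fold higher number from compound 3 to compound 4 (2.11 log units; beyond the scatter) and, for the single methyl, a 73000-fold higher number from compound 1 to compound 4 (4.87 log units; beyond the scatter) as a still larger step. Phenyl recovers little by comparison, with a 2.5-fold higher number from compound 2 to compound 4 (0.41 log units; beyond the scatter) as the whole of its difference from the bare ring. The methyl groups, not the ring alone, therefore go with the low numbers. From the compounds shown here alone, whether an ethyl, methoxy or hydroxyl group on this ring carbon would do the same remains open. Nothing given here explains the size of these steps.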